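The source may report more compounds than this note shows. Statements on the series, on what has been measured and on what is new or still open speak of the compounds shown alone.

In a functional assay on HT-29 cells (Homo sapiens) for inhibition, read by MTT assay, with a stated time of 96 h (on this read-out higher numbers stand for weaker inhibition of growth and lower numbers for stronger inhibition of growth), compound 1 `O=C(NCCCCCCSSCCCCCCNC(=O)c1cc(-c2ccncc2)n[nH]1)c1cc(-c2ccncc2)n[nH]1` gives 6920 nM, compound 2 `O=C(OCc1ccccc1)SCCCCCCNC(=O)c1cc(-c2ccncc2)n[nH]1` gives 22000 nM and compound 3 `C=CCOC(=O)SCCCCCCNC(=O)c1cc(-c2ccncc2)n[nH]1` gives 11900 nM. The value of compound 3 lies within the usual scatter of both other values. Compound 4 `CCC(=O)SCCCCCCNC(=O)c1cc(-c2ccncc2)n[nH]1` differs from compound 3 as follows: ethyl in place of allyloxy on a carbonyl carbon. For the measured compounds named here, only one measured step bears on this change, a 1.8-fold lower number from compound 2 to compound 3 (0.27 log units; within the scatter), and it replaces vinyl for phenyl rather than the allyloxy group itself. On that thin evidence, no step beyond the scatter is expected in this assay, and no direction can be assigned. The expected change is a 1.1-fold lower number from compound 3 to compound 4 (0.03 log units; within the scatter). The estimate for compound 4 is 11000 nM, with an expected range of 5000 nM to 25000 nM.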

Compound 4, concentration for 50% growth inhibition: > 50000 nM
Compound 4: no number, only a limit; the forecaster's own chance of this, stated with the estimate: 5%; middle value at least 4.5-fold (0.65 log units) from the limit.
By their numbers in this assay, from the lowest: compounds 1, 3 and 2 (each within the scatter of the next, the first and the last beyond it). At a limit, above all of these: compound 4.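

In this assay compound 4 stands at a limit, > 50000 nM, and not at a number. On this carbonyl carbon, whose other neighbour is sulfur, exchanging benzyloxy for allyloxy gave only a 1.8-fold lower number from compound 2 to compound 3 (0.27 log units; within the scatter), whereas ethyl gives an at least 4.2-fold higher number from compound 3 to compound 4 (0.62 log units; beyond the scatter) and an at least 2.2-fold higher number from compound 2 to compound 4 (0.35 log units; beyond the scatter). The position therefore responds to this change, with weaker inhibition of growth for ethyl than for either oxygen-bearing group.

As far as these compounds go, whether the oxygen or the size of the group matters remains open. Methoxy, an amine or a longer chain such as butyl on this carbonyl carbon would help separate the two.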